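This account rests on a few compounds, and the source may have more. Where it says the series, first, only, none or still open, it means among the compounds named here.

Measured in an ADME assay on A549 cells (Homo sapiens) for cytotoxicity, read by resazurin assay, with a stated time of 48 h; a higher number here means that more compound is tolerated, a lower number that less compound is tolerated:
- compound 1 `O=C(Nc1ccc(NCC2CCCC2)cc1Cl)c1cc(Cl)ccc1O`: 21500 nM
- compound 2 `O=C(Nc1ccc(NCc2ccc(F)cc2)cc1Cl)c1cc(Cl)ccc1O`: 54400 nM
- compound 3 `O=C(Nc1ccc(NCc2ccc(Br)cc2)cc1Cl)c1cc(Cl)ccc1O`: 40900 nM

Compound 3 lies within the scatter of both other compounds, as a 1.3-fold lower number from compound 2 to compound 3 (0.12 log units; within the scatter) and a 1.9-fold higher number from compound 1 to compound 3 (0.28 log units; within the scatter) show. Compound 4 `O=C(Nc1ccc(NCc2cccc(C(F)(F)F)c2)cc1Cl)c1cc(Cl)ccc1O` is the next structure, and it differs from compound 3 as follows: 3-(trifluoromethyl)phenyl in place of 4-bromophenyl on a saturated chain carbon bound to a nitrogen on an aromatic ring. The step closest to this change is the bromo for fluoro exchange already cited, which stayed within the scatter. Only the exchange of cyclopentyl for 4-fluorophenyl, a 2.5-fold higher number from compound 1 to compound 2 (0.40 log units; beyond the scatter), went beyond it, and modestly. Compound 4 keeps a phenyl ring at this place, so no step beyond the scatter is expected in this assay. The expected change is a 1.1-fold lower number from compound 3 to compound 4 (0.06 log units; within the scatter). For compound 4 the estimated value is 36000 nM, with an expected range of 16000 nM to 80000 nM.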

Compound 4, half-maximal cytotoxic concentration: 13300 nM
Beside the measured number, compound 4's estimate is 2.7-fold (0.43 log units) above it, and the stated range ends above it.
By their numbers in this assay, from the lowest: compounds 4, 1, 3 and 2 (each within the scatter of the next, the first and the last beyond it).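

In this assay, exchanging one substituted phenyl group for another at this place can go beyond the scatter (a 3.1-fold lower number from compound 3 to compound 4 (0.49 log units; beyond the scatter); a 4.1-fold lower number from compound 2 to compound 4 (0.61 log units; beyond the scatter)), which the bromo for fluoro exchange did not do. A phenyl ring here therefore does not by itself keep the number apart from that of cyclopentyl (a 1.6-fold lower number from compound 1 to compound 4 (0.21 log units; within the scatter)). No evidence at hand accounts for this result. The compounds shown leave open whether the trifluoromethyl group or its ring position drives the step, which 4-(trifluoromethyl)phenyl would separate. They also leave open how a pyridine ring would behave here.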